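The compounds below may be only part of what the source reports. "The series", "measured", "known", "first", "only" and "open" are said of these compounds alone.

The compounds here share one core, first shown in compound 1 `O=C(Nc1ccccc1)C1C(=O)N(O)C(=O)c2ccccc21`, and differ only in the group attached at the amide-type nitrogen. In an ADME assay on MT4 cells (Homo sapiens) for cytotoxicity, read by MTT assay (on this read-out higher numbers stand for lower toxicity in this test and lower numbers for higher toxicity in this test), compound 1 gives 106000 nM. Compound 2 `O=C(Nc1ccc(F)cc1)C1C(=O)N(O)C(=O)c2ccccc21` carries fluoro in place of hydrogen on an aromatic carbon, and in this assay compound 2 gives 115000 nM, which is a 1.1-fold higher number from compound 1 to compound 2 (0.04 log units; within the scatter). Compound 3 `Cc1ccc(CNC(=O)C2C(=O)N(O)C(=O)c3ccccc32)cc1` carries 4-methylbenzyl in place of phenyl on the amide-type nitrogen. In this assay compound 3 reaches only a limit of the measurement, > 125000 nM. Against compound 1 this is an at least 1.1-fold higher number from compound 1 to compound 3 (0.07 log units; that floor lies within the scatter), and against compound 2 it is an at least 1.0-fold higher number from compound 2 to compound 3 (0.03 log units; that floor lies within the scatter); the limit of > 125000 nM in this assay, at which 1 of the 3 values shown sits, marks where compound 3 sits.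

Compound 4 `O=C(NCc1ccc(O)c(O)c1)C1C(=O)N(O)C(=O)c2ccccc21` has not yet been measured. It differs from compound 3 in one place: 3,4-dihydroxyphenyl in place of 4-methylphenyl on a saturated chain carbon bound to an amide-type nitrogen. None of the three measured steps brings in a group like 3,4-dihydroxyphenyl, and all of them fall within the scatter, so among these compounds the group on this side of the core has moved the read-out little. Compound 4 is therefore expected to show a step of a number no higher from compound 3 to compound 4 (the limit leaves the size open) in this assay, nothing beyond the scatter. Compound 4 is estimated at 125000 nM, within a range from 70000 nM to 250000 nM, with a fair chance that again only a limit is reported.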

Compound 4, half-maximal cytotoxic concentration: 11000 nM
Estimate against measurement, compound 4: 11-fold (1.06 log units) above, and the stated range ends above it.
By their numbers in this assay, from the lowest: compound 4; then compounds 1 and 2 (each within the scatter of the next). At a limit, above all of these: compound 3.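

In this assay, putting 3,4-dihydroxyphenyl in place of 4-methylphenyl on a saturated chain carbon bound to an amide-type nitrogen gives an at least 11-fold lower number from compound 3 to compound 4 (1.05 log units; beyond the scatter). This shows that the group on this side of the shared core can change the read-out strongly, and here the change is toward higher toxicity in this test, whereas an earlier change on the same side, a 1.1-fold higher number from compound 1 to compound 2 (0.04 log units; within the scatter), did not move it beyond the scatter. The true size of the new step stays unknown, because the number for compound 3 is only a limit of the assay, so the step printed is a floor: the limit of > 125000 nM in this assay, at which 1 of the 4 values shown sits.

What the compounds shown leave open is which feature of the 3,4-dihydroxyphenyl group matters: whether a phenyl with a single hydroxy group, or one with two methoxy groups in place of the two hydroxy groups, would bring the same drop. They also leave open whether the two hydroxy groups would have the same effect with no saturated chain carbon in between, on a phenyl bound directly to the amide-type nitrogen as in compound 1.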